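Hydroxy in place of methoxy on a limit-bound series

The source may report more compounds than this note shows. Statements on the series, on what has been measured and on what is new or still open speak of the compounds shown alone.

In a functional assay on SNB-19 cells (Homo sapiens) for inhibition, read by sulforhodamine B assay, with a stated time of 48 h (a lower number here means a stronger inhibitor of growth, a higher number a weaker inhibitor of growth), compound 3 `COc1cc(C)cc(-c2nn(CC#N)cc2-c2ccnc(-c3ccc(N(C)C)cc3)c2)c1` gives > 100000 nM, which is a limit of the assay and not a number. Compound 3 therefore stands at the limit of > 100000 nM in this assay, at which 2 of the 3 values shown sit, and its own position cannot be placed more closely. Compound 1 `COc1cc(C)cc(-c2c(-c3ccnc(-c4ccc(C(C)=O)cc4)c3)cnn2CC#N)c1` likewise gives > 100000 nM, again a limit. For the measured compounds named here, the single number among the three comes from compound 2 `Cc1cc(O)cc(-c2nn(CC#N)cc2-c2ccnc(-c3ccc(Oc4ccccc4)cc3)c2)c1`, which gives 23400 nM in this assay.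

Compound 4 `Cc1cc(O)cc(-c2nn(CC#N)cc2-c2ccnc(-c3ccc(N(C)C)cc3)c2)c1` is compound 3 with hydrogen in place of methyl on an oxygen on an aromatic ring. Going by the values given here, no measured step connects compound 3 to any neighbour, and the only pointer is that compound 2, which carries the hydroxy group, is the one compound with a number. Because compound 3 shows only the limit > 100000 nM, the expected step of an at least 1.6-fold lower number from compound 3 to compound 4 (0.22 log units; that floor lies within the scatter) in this assay is a modest move toward stronger growth inhibition, with a real chance that compound 4 again shows only a limit. Compound 4 is estimated at 60000 nM, within a range from 15000 nM to 200000 nM.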

Compound 4, concentration for total growth inhibition: 43900 nM
Beside the measured number, compound 4's estimate is 1.4-fold (0.14 log units) above it, within the range that was stated.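

For the compounds shown here, the change from 3-methoxy-5-methylphenyl to 3-hydroxy-5-methylphenyl gives an at least 2.2-fold lower number from compound 3 to compound 4 (0.35 log units; beyond the scatter) in this assay, a direct reading of this position that the earlier compounds, with no pair differing in one place, could not give. The size of that step remains only a floor, because compound 3 carries a limit of the assay and not a number: the limit of > 100000 nM in this assay, at which 2 of the 4 values shown sit. The second pair, with a 1.9-fold higher number from compound 2 to compound 4 (0.27 log units; within the scatter), shows that with hydroxy in place, dimethylamino and phenoxy on that aromatic carbon cannot be told apart in this measure.

From the compounds shown here alone, whether methoxy in place of hydroxy would also return compound 2 to the limit remains open. So does what an amine or a carboxylic acid in place of hydroxy on the same aromatic ring would do to growth inhibition.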